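Series notes: from compound 1 to compound 4

A few compounds are considered here, and "the series" means these few. Any claim that something is new, unique, unknown or untested is made for them only; others in the source may bear on it.

Compound 1 `Cn1c(=O)c(S(=O)(=O)c2ccc(F)cc2F)cc2cnc(Nc3cccc4[nH]ccc34)nc21` gives 750 nM in a functional assay on DU-145 cells (Homo sapiens) for inhibition, read by trypan blue exclusion, with a stated time of 72 h; on this read-out higher numbers stand for weaker inhibition and lower numbers for stronger inhibition. Compound 2 `Cn1c(=O)c(S(=O)(=O)c2ccc(F)cc2)cc2cnc(Nc3cccc4[nH]ccc34)nc21` gives 750 nM in this assay, so the two stand level and together hold the lowest of the three numbers; the step of no change at the digits printed from compound 1 to compound 2 (within the scatter) lies within the scatter. Compound 3 `Cc1ccc(S(=O)(=O)c2cc3cnc(Nc4ccc5cc[nH]c5c4)nc3n(C)c2=O)cc1` differs from compound 1 in several places. In this assay compound 3 gives 15000 nM, a markedly higher number. Compound 4 `Cn1c(=O)c(S(=O)(=O)c2ccc(F)cc2F)cc2cnc(Nc3ccc4cccc(O)c4n3)nc21` differs from compound 1 in one place: 8-hydroxyquinolin-2-yl in place of 1H-indol-4-yl on a nitrogen on an aromatic ring. Among the measured compounds shown here, no measured step touches this part of the molecule; the single recorded step concerns a fluoro on an aromatic carbon and shows no change. The expectation for compound 4 is therefore wide and centred on a modest weakening, a 2.7-fold higher number from compound 1 to compound 4 (0.43 log units; beyond the scatter). Compound 4 is estimated at 2000 nM, within 400 nM to 15000 nM.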

Compound 4, half-maximal inhibitory concentration: 5000 nM
Beside the measured number, compound 4's estimate is 2.5-fold (0.40 log units) below it; the measured number falls inside the stated range.
By their numbers in this assay, from the lowest: compounds 1 and 2 (each within the scatter of the next); then compound 4; then compound 3.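

In this assay, replacing 1H-indol-4-yl with 8-hydroxyquinolin-2-yl on a nitrogen on an aromatic ring gives a 6.7-fold higher number from compound 1 to compound 4 (0.82 log units; beyond the scatter), a step beyond the scatter. Among the compounds shown here, this position therefore responds to the group it carries, which the only earlier step, no change at the digits printed from compound 1 to compound 2 (within the scatter), at a fluoro on an aromatic carbon, could not show. No available evidence explains this step.

The compounds shown do not separate the hydroxy group from the quinoline ring. Also open, on these data alone, is how a quinolin-2-yl carrying a methoxy group or an amine instead of the hydroxy would stand.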